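Difluoromethyl for imidazolyl on a quinoline acrylic acid

The source may report more compounds than this note shows. Statements on the series, on what has been measured and on what is new or still open speak of the compounds shown alone.

Measured in a physicochemical assay for lipophilicity, using the shake flask method; a higher number here means a more lipophilic compound, a lower number a more polar compound:
- compound 1 `C[C@H](Oc1ccc2ncc(S(=O)(=O)CC(=O)O)c(C3CC3)c2c1)c1c(Cl)ccc(F)c1Cl`: 2.5
- compound 2 `C[C@H](Oc1ccc2nc(OCCN)c(CCC(=O)O)c(C3CC3)c2c1)c1c(Cl)ccc(F)c1Cl`: 3.8
- compound 3 `C[C@H](Oc1ccc2ncc(/C=C/C(=O)O)c(-n3ccnc3)c2c1)c1c(Cl)ccc(F)c1Cl`: 2

Of the compounds shown here, three sharing one core have been measured in this assay. Compound 3 stands lowest of the three, with compound 1 sitting higher by a gap beyond the scatter, and compound 2 furthest away, also beyond the scatter. Within the data shown here, none of the three differs from another in a single place, so no step between measured compounds can be read off.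

Among the measured compounds shown here, compound 4 `C[C@H](Oc1ccc2ncc(/C=C/C(=O)O)c(C(F)F)c2c1)c1c(Cl)ccc(F)c1Cl` is the only compound here that differs from a measured one in a single place: difluoromethyl in place of 1H-imidazol-1-yl on an aromatic carbon. The group that leaves carries two hydrogen-bond acceptors and a five-membered aromatic ring; the group that enters carries none of these, with three heavy atoms in place of five.

For the measured compounds named here, no measured pair shows what this change does in this assay. On the structural count alone, compound 4 is expected to read higher than compound 3 by a step of about a number 1.20 log units higher from compound 3 to compound 4 (beyond the scatter), beyond the scatter. The estimate for compound 4 in this assay is therefore 3.2, with a range from 2.6 to 3.8.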

Compound 4, distribution coefficient: 3.1
For compound 4 the middle estimate is 0.10 log units above the measured one; the range from low to high includes it.
By their numbers in this assay, from the lowest: compound 3; then compound 1; then compound 4; then compound 2.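

Among these compounds, the exchange of 1H-imidazol-1-yl for difluoromethyl, on the aromatic carbon opposite the ring nitrogen and ortho to a 2-carboxyethenyl group, gives the first step in this assay that can be tied to a single place: a number 1.10 log units higher from compound 3 to compound 4 (beyond the scatter). The earlier compounds shown here differed from one another in more than one place, so they could not show what any one position contributes; this pair shows that a change at this position alone, with the rest of the structure unchanged, can move the reading by a large step. The result rests on this one pair, and no measurement shown here accounts for the size of the step.

The pair cannot separate the removal of the five-membered aromatic ring from the arrival of the two fluorine atoms, and a methyl or a trifluoromethyl group on the same carbon would be needed to tell these apart. It also leaves open whether the exchange gives a step of similar size when a primary amide stands in place of the 2-carboxyethenyl group.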